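From Cyclobutylmethyl to Oxolan-3-yl on an Amide-Type Nitrogen

This account rests on a few compounds, and the source may have more. Where it says the series, first, only, none or still open, it means among the compounds named here.

In a physicochemical assay for solubility, read by chemiluminescence (a higher number here means a more soluble compound, a lower number a less soluble compound), compound 1 (`O=C(CN(C(=O)c1ccc(-c2ccccn2)cc1)C1CCCCC1)Nc1cc(F)cc(F)c1`) gives 6 ug/mL and compound 2 (`O=C(CN(CC1CCC1)C(=O)c1ccc(-c2ccccn2)cc1)Nc1cc(F)cc(F)c1`) gives 7 ug/mL on the same scale. Going by the values given here, these two compounds are linked by the only measured step, which places cyclobutylmethyl where cyclohexyl stood on an amide-type nitrogen. That step is a 1.2-fold higher number from compound 1 to compound 2 (0.07 log units; within the scatter) and so leaves compound 2 level with compound 1.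

Compound 3 (`O=C(CN(C(=O)c1ccc(-c2ccccn2)cc1)C1CCOC1)Nc1cc(F)cc(F)c1`) changes the same substituent again, with oxolan-3-yl in place of cyclobutylmethyl on an amide-type nitrogen. The measured step bears on this change only in part, since it exchanged one carbon-only group for another, whereas oxolan-3-yl brings in a hetero atom. Among the compounds with values here, no measured pair shows such an exchange, so the expectation rests on the structural change and on compound 2 at 7 ug/mL as its starting point. A moderate rise is expected, although a step within the scatter remains possible. The estimated step is a 2.0-fold higher number from compound 2 to compound 3 (0.30 log units; within the scatter) in this assay and carries wide uncertainty. Compound 3 is therefore estimated at 14 ug/mL (range 6 ug/mL to 35 ug/mL).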

Compound 3, solubility: 102 ug/mL
The estimate for compound 3 lay 7.3-fold (0.86 log units) below the measured number, and the stated range ends below it.
By their numbers in this assay, from the lowest: compounds 1 and 2 (each within the scatter of the next); then compound 3.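

At this position on an amide-type nitrogen, the earlier pair had shown only a change among carbon-only groups, whereas in this assay the change to oxolan-3-yl gives a 15-fold higher number from compound 2 to compound 3 (1.16 log units; beyond the scatter) and, set against the cyclohexyl group, gives a 17-fold higher number from compound 1 to compound 3 (1.23 log units; beyond the scatter) as well. Both steps are large and beyond the scatter, so this position can shift the read-out strongly, even though cyclobutylmethyl and oxolan-3-yl have the same number of heavy atoms. Among these three compounds, only compound 3 has a hetero atom and a hydrogen-bond acceptor in this group, and it alone stands apart from the others, but nothing measured here accounts for the size of the step.

The change from compound 2 to compound 3 alters the ring size, the oxygen and the ring's attachment together, so these compounds cannot show which of these differences matters. As far as these compounds go, a cyclopentyl group would hold the five-membered ring while keeping only carbon, whereas a pyrrolidin-3-yl group would put a ring nitrogen where oxolan-3-yl has its oxygen, and the outcome with either group remains open.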